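The source may hold more compounds than are shown below. What is called first, only, known or untested is meant among the compounds shown, and "the series" means these compounds.

Of the compounds shown here, three built on one shared core have been measured. Compound 1 `CC(C)(C)Cc1csc(N)c1C(=O)c1ccc(Cl)cc1` carries hydrogen at the carbon of interest, and in an assay on CHO cells for displacement of a labelled ligand from adenosine receptor A1 (Homo sapiens), read by scintillation counting, tested at 10 uM (a lower number here means less inhibition, a higher number more inhibition at the concentration tested (going by the name of the read-out)), compound 1 gives 1%. In this assay compound 2 `CC(C)(C)Cc1c(-c2cccc(F)c2F)sc(N)c1C(=O)c1ccc(Cl)cc1` gives 1%, and compound 3 `CC(C)(C)Cc1c(-c2ccc(Cl)c(Cl)c2)sc(N)c1C(=O)c1ccc(Cl)cc1` gives 1%. Compound 3 therefore stands level with the other two at the digits shown: the step of no change at the digits printed from compound 1 to compound 3 (within the scatter) and the step of no change at the digits printed from compound 2 to compound 3 (within the scatter) both lie within the scatter, as does no change at the digits printed from compound 1 to compound 2 (within the scatter). The next compound, compound 4 `CC(C)(C)Cc1c(-c2cccs2)sc(N)c1C(=O)c1ccc(Cl)cc1`, differs from compound 3 in one place: thiophen-2-yl in place of 3,4-dichlorophenyl on an aromatic carbon. The three steps just named bear on this change, and each of them was flat. Two different substituents at this carbon did not move the read-out beyond the scatter relative to hydrogen, so a third substituent there is expected to behave the same way, and the step of a number 1 percentage points higher from compound 3 to compound 4 (within the scatter) is expected to stay within the scatter. Compound 4 is therefore estimated at 2%, with a range from 0% to 12%.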

Compound 4, a percentage reported as inhibition, at one concentration (the size of the read-out at that concentration, not a potency): 1%
Estimate against measurement, compound 4: 1 percentage points above, and the stated range covers the measured number.
By their numbers in this assay, from the lowest: compounds 1, 2, 3 and 4 (each within the scatter of the next).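

In this assay, the step of no change at the digits printed from compound 3 to compound 4 (within the scatter) shows that the read-out also holds when a six-membered carbon ring gives way to a smaller five-membered ring carrying a sulfur atom and a hydrogen-bond acceptor. The picture is the same against the 2,3-difluorophenyl group and against plain hydrogen, with the steps of no change at the digits printed from compound 2 to compound 4 (within the scatter) and no change at the digits printed from compound 1 to compound 4 (within the scatter), so neither ring size nor the ring sulfur separates these compounds at this carbon. Nothing available explains this flat result.

From the compounds shown here alone, all four compounds read close to zero, so it remains open whether an aminomethyl group or a carboxylic acid at this carbon would give any real inhibition. Going by these compounds, it is equally open whether a longer chain in place of the neopentyl group would do so.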